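Hydroxy to Benzyloxy: Estimating a Toxicity Shift

The compounds below may be only part of what the source reports. "The series", "measured", "known", "first", "only" and "open" are said of these compounds alone.

Of the compounds shown here, three sharing a chlorinated core have been tested in an ADME assay on Huh-7 cells (Homo sapiens) for cytotoxicity, read by XTT assay; on this read-out lower numbers stand for higher toxicity in this test and higher numbers for lower toxicity in this test. Compound 1 `OC[C@H]1C[C@@H](n2cnc3c(Cl)ncnc32)[C@@H]1CO` reaches only a limit of the test, > 200000 nM, so it gives no exact number. Compound 2 `OC[C@H]1O[C@@H](n2cnc3c(Cl)ncnc32)C[C@@H]1O` gives 173000 nM, the higher of the two exact numbers. Compound 3 `O=C(OC[C@@H]1C[C@@H](O)[C@H](n2cnc3c(Cl)ncnc32)O1)c1ccccc1`, which carries a six-membered aromatic ring of carbon only, gives 70500 nM, a lower number by more than the usual scatter.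

Compound 4 `O[C@H]1C[C@H](n2cnc3c(Cl)ncnc32)O[C@@H]1COCc1ccccc1` has not yet been measured. It differs from compound 2 by benzyl in place of hydrogen on an oxygen on a saturated carbon, so a hydroxy group becomes a benzyloxy group. Within the data shown here, no measured pair isolates this change, so the only guide is the ring-bearing compound 3 at 70500 nM, and that comparison is loose. The expected change is a moderate move toward higher toxicity, a 2.9-fold lower number from compound 2 to compound 4 (0.46 log units; beyond the scatter), probably beyond the scatter. For compound 4, the estimated value in this assay is 60000 nM, with an expected range of 20000 nM to 150000 nM.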

Compound 4, half-maximal cytotoxic concentration: 178000 nM
The estimate for compound 4 lay 3.0-fold (0.47 log units) below the measured number; measured number above the stated range.
By their numbers in this assay, from the lowest: compound 3; then compounds 2 and 4 (each within the scatter of the next). At a limit, above all of these: compound 1.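

At this place, on an oxygen on a saturated carbon, the change from hydroxy to benzyloxy gives a 1.0-fold higher number from compound 2 to compound 4 (0.01 log units; within the scatter) in this assay, so here benzyl, with its six-membered aromatic ring of carbon only, brings no lower number. Compound 4 differs from compound 3 in more than one place, so compound 3, at 70500 nM, cannot be read as a measure of this change. This pair also leaves little room to see a rise in the number, because both of its values lie close to one mark of the test: the limit of > 200000 nM in this assay, at which 1 of the 4 values shown sits.

From the compounds shown here alone, whether an amine, a carboxylic acid or a longer chain on this oxygen would leave the number just as unchanged stays open. This single pair also cannot tell whether benzyloxy would behave the same way on another core.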